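Trifluoromethyl for Methoxy on a Growth-Inhibition Anilide

The source may report more compounds than this note shows. Statements on the series, on what has been measured and on what is new or still open speak of the compounds shown alone.

Measured compounds:
compound 1 `COc1ccc(NC(=O)C2(C(=O)Nc3ccc(Nc4ncc5cc(C(=O)N(C)C)n(C6CCCC6)c5n4)cc3)CC2)cc1`, 76.4%
compound 2 `Nc1ccc(NC(=O)C2(C(=O)Nc3ccc(F)cc3)CC2)cc1F`, 5.6%

In a functional assay on T47D cells (Homo sapiens) for inhibition, read by CCK-8 assay, with a stated time of 72 h, tested at 1 uM (on this read-out higher numbers stand for more inhibition of growth at the one concentration tested and lower numbers for less inhibition of growth), compound 1 gives 76.4%, the higher of the two numbers measured; compound 2 gives 5.6%, a gap beyond the scatter. Compound 3 `CN(C)C(=O)c1cc2cnc(Nc3ccc(NC(=O)C4(C(=O)Nc5ccc(C(F)(F)F)cc5)CC4)cc3)nc2n1C1CCCC1` is not yet measured. It differs from compound 1 in one place: trifluoromethyl in place of methoxy on an aromatic carbon. Among the measured compounds shown here, no measured pair shows that change, so its effect is open. Compound 3 keeps the core of compound 1, and its inhibition is expected near that of compound 1, with a step of a number 4.4 percentage points lower from compound 1 to compound 3 (within the scatter) not beyond the scatter. Compound 3 is therefore estimated at 72%, between 50% and 90%.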

Compound 3, percent growth inhibition at one concentration: 29.6%
The estimate for compound 3 lay 42.4 percentage points above the measured number, outside the stated range (below it).
By their numbers in this assay, from the lowest: compound 2; then compound 3; then compound 1.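

In this assay, trifluoromethyl in place of methoxy on an aromatic carbon, para to a large group, gives a number 46.8 percentage points lower from compound 1 to compound 3 (beyond the scatter). Among the compounds shown here, with the core of compound 1 kept, this single change shows that the group at this place matters to growth inhibition, which no earlier pair could show. Nothing at hand accounts for the step.

On these data alone, whether an amine, a hydroxyl group or a plain hydrogen at this place would read nearer compound 1 or compound 3 stays open. So does whether the step holds at other concentrations.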